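The source may report more compounds than this note shows. Statements on the series, on what has been measured and on what is new or still open speak of the compounds shown alone.

Measured so far in a functional assay on the whole organism (strain albino) with Mus musculus as the target, in the maximal electroshock model, with a stated time of 0.5 h; on this read-out higher numbers stand for an effect only at larger amounts of compound and lower numbers for an effect already at smaller amounts:
compound 1, `Cc1ccccc1Nc1nnc(Nc2nc(-c3ccc(Br)cc3)cs2)s1`: 300 mg/kg
compound 2, `Cc1ccc(Nc2nnc(Nc3nc(-c4ccc(Br)cc4)cs3)s2)cc1`: 100 mg/kg

For the measured compounds named here, compound 2 stands at the lowest of the two numbers; its only neighbour is compound 1, and the step of a 3.0-fold lower number from compound 1 to compound 2 (0.48 log units; beyond the scatter) is beyond the scatter. Compound 3, `COc1ccccc1Nc1nnc(Nc2nc(-c3ccc(Br)cc3)cs2)s1`, is not yet measured in this assay. It differs from compound 2 in one place: 2-methoxyphenyl in place of 4-methylphenyl on a nitrogen on an aromatic ring. Going by the values given here, one measured step bears on this change. The step of a 3.0-fold lower number from compound 1 to compound 2 (0.48 log units; beyond the scatter) went from 2-methylphenyl to 4-methylphenyl, and compound 3 carries 2-methoxyphenyl, whose name stands nearer to the 2-methylphenyl of compound 1 than to the 4-methylphenyl of compound 2. Among the compounds with values here, no measured pair separates methyl from methoxy, so that part of the change is untested. The expected direction is therefore a higher number, of roughly the size of the measured step reversed, estimated as a 3.0-fold higher number from compound 2 to compound 3 (0.48 log units; beyond the scatter). Compound 3 is expected to give about 300 mg/kg, in the range 100 mg/kg to 600 mg/kg.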

Compound 3, minimum effective dose: 300 mg/kg
Beside the measured number, compound 3's estimate shows no gap at the digits printed; measured number inside the range.
By their numbers in this assay, from the lowest: compound 2; then compounds 1 and 3 (each within the scatter of the next).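

In this assay, for the compounds shown here, methoxy in place of methyl on an aromatic carbon gives the first measured pair at this position, and it shows no change at the digits printed from compound 1 to compound 3 (within the scatter). Compound 3 also shows that 2-methoxyphenyl, like 2-methylphenyl, stands apart from the 4-methylphenyl of compound 2, with a 3.0-fold higher number from compound 2 to compound 3 (0.48 log units; beyond the scatter), so among these three compounds the lowest number belongs to the 4-methylphenyl group alone and none goes against this. No measurement here explains this difference.

Going by these compounds, whether methoxy would match methyl when carried as in the 4-methylphenyl of compound 2 stays open, so the effect of where the group sits is only partly separated from the effect of which group it is. On these data alone, a plain phenyl, or a phenyl carrying an amine or a carboxylic acid, on the same nitrogen also remains open.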